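A few compounds are considered here, and "the series" means these few. Any claim that something is new, unique, unknown or untested is made for them only; others in the source may bear on it.

Of the compounds shown here, two have been measured. Compound 1 `CCOC(=O)C1=C(N/N=C(\C#N)C(N)=O)Nc2[nH]nc(C)c2C1c1ccc(N(C)C)cc1` gives 48400 nM in a functional assay on HepG2 cells (Homo sapiens) for inhibition, read by MTT assay, with a stated time of 48 h (a higher number here means a weaker inhibitor, a lower number a stronger inhibitor), and compound 2 `CCOC(=O)C1=C(N/C=N/c2ccccn2)Nc2[nH]nc(C)c2C1c1ccc(N(C)C)cc1` gives 26200 nM in this assay. Within the data shown here, the only step between them, a 1.8-fold lower number from compound 1 to compound 2 (0.27 log units; within the scatter), exchanged a chain group for a ring group on the amine nitrogen and stayed within the scatter, so compound 2 and compound 1 cannot be told apart on these numbers; compound 2 is simply the point of departure here. Compound 3 `CCOC(=O)C1=C(N/N=C(/C(C)=O)C(=O)OCC)Nc2[nH]nc(C)c2C1c1ccc(N(C)C)cc1` carries the change (a group of 10 heavy atoms (6 carbon, 1 nitrogen, 3 oxygen; no ring) in place of a group of 8 heavy atoms (6 carbon, 2 nitrogen; one six-membered aromatic ring with 1 hetero atom), on an amine nitrogen), which returns a chain, now of a different make-up, to the same nitrogen. Among the measured compounds shown here, with the one relevant step within the scatter, no step beyond the scatter is expected from compound 2 to compound 3 in this assay, that is a 1.3-fold higher number from compound 2 to compound 3 (0.13 log units; within the scatter). Compound 3 is therefore estimated at 35000 nM in this assay, with a range from 12000 nM to 100000 nM.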

Compound 3, half-maximal inhibitory concentration: > 100000 nM
Compound 3 ended at the assay's limit; the forecaster's own chance of this, stated with the estimate: 10%; middle value at least 2.8-fold (0.45 log units) away from the limit.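

The group on this amine nitrogen does matter in this assay, since the chain of 10 heavy atoms in compound 3 gives an at least 3.8-fold higher number from compound 2 to compound 3 (0.58 log units; beyond the scatter) and an at least 2.0-fold higher number from compound 1 to compound 3 (0.31 log units; beyond the scatter), whereas the earlier exchange stayed within the scatter. This is not simply ring against chain, as compound 1 also carries a chain with no ring and cannot be told apart from compound 2. Compound 3 stands at a limit of the assay, not at a number, so both steps give only a minimum size: the limit of > 100000 nM in this assay, at which 1 of the 3 values shown sits.

Going by these compounds, how far compound 3 lies beyond that limit stays open, as does which part of its chain goes with the weaker inhibition. A phenyl ring or a short alkyl chain on this nitrogen would test whether the change follows the make-up of the group or its size.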